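The source may report more compounds than this note shows. Statements on the series, on what has been measured and on what is new or still open speak of the compounds shown alone.

Three compounds have been measured in a functional assay on MGC-803 cells (Homo sapiens) for cytotoxicity, read by MTT assay, with a stated time of 72 h; a lower number here means a stronger inhibitor, a higher number a weaker inhibitor:

Compound 1, `CCCCCCNc1nc(SCc2ccc(C(F)(F)F)cc2)nc2ccccc12`, gives 13100 nM.
Compound 2, `FC(F)(F)c1ccc(CSc2nc(Nc3cccc(C(F)(F)F)c3)c3ccccc3n2)cc1`, gives 15100 nM.
Compound 3, `FC(F)(F)c1ccc(CSc2nc(Nc3cccc(Br)c3)c3ccccc3n2)cc1`, gives 23700 nM.

Compound 3 stands at the highest of the three numbers, yet its distance from compound 2 (a 1.6-fold higher number from compound 2 to compound 3 (0.20 log units; within the scatter)) and from compound 1 (a 1.8-fold higher number from compound 1 to compound 3 (0.26 log units; within the scatter)) both sit within the scatter, so the three compounds cannot be told apart on these results. The step from compound 1 to compound 2, a 1.2-fold higher number from compound 1 to compound 2 (0.06 log units; within the scatter), is also within the scatter.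

Compound 4, `FC(F)(F)c1ccc(CSc2nc(Nc3ccc(Cl)cc3)c3ccccc3n2)cc1`, has not yet been measured. It differs from compound 3 in one place: 4-chlorophenyl in place of 3-bromophenyl on a nitrogen on an aromatic ring. Among the measured compounds shown here, the step that bears on it most directly is the one from compound 2 to compound 3, where one halogen-type substituent on the aromatic carbon replaced another and the number moved only within the scatter. All three measured changes at this nitrogen, whether a chain or a substituted phenyl, left the number in the same band. For compound 4 the expected step is therefore a 1.2-fold lower number from compound 3 to compound 4 (0.07 log units; within the scatter), none beyond the scatter. Compound 4 is estimated at 20000 nM in this assay, within a range from 8000 nM to 50000 nM.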

Compound 4, half-maximal inhibitory concentration: 16800 nM
Beside the measured number, compound 4's estimate is 1.2-fold (0.08 log units) above it, and the stated range covers the measured number.
By their numbers in this assay, from the lowest: compounds 1, 2, 4 and 3 (each within the scatter of the next).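

In this assay, 4-chlorophenyl in place of 3-bromophenyl on the nitrogen gives a 1.4-fold lower number from compound 3 to compound 4 (0.15 log units; within the scatter); this one change alters both the halogen and its place in the group's name, and still no difference can be read. Compound 4 also cannot be told apart from the compounds carrying the other two groups at this nitrogen, with a 1.1-fold higher number from compound 2 to compound 4 (0.05 log units; within the scatter) against 3-(trifluoromethyl)phenyl and a 1.3-fold higher number from compound 1 to compound 4 (0.11 log units; within the scatter) against hexyl. A hexyl chain and three different substituted phenyl groups on this nitrogen now all lie within the scatter of one another, and no measurement at hand offers an explanation for this.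

The compounds shown do not tell whether any group on this nitrogen can move the number beyond the scatter, for example a chain ending in an amine or a phenyl carrying a carboxylic acid. They also leave open whether an unsubstituted phenyl or a chain much shorter than hexyl would stay in the same band.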